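A few compounds are considered here, and "the series" means these few. Any claim that something is new, unique, unknown or untested is made for them only; others in the source may bear on it.

Three compounds have been measured in a functional assay on A-375 cells (Homo sapiens) for antiproliferative activity, read by CCK-8 assay, with a stated time of 72 h, tested at 8 uM; a higher number here means a stronger effect of the compound at the concentration tested, a lower number a weaker effect:

compound 1, `Nc1ccccc1NC(=O)c1ccc(CSC(=S)N2CCN(c3ccc(F)cc3)CC2)cc1`, gives 76.3%
compound 2, `CC1CCN(C(=S)SCc2ccc(C(=O)Nc3ccccc3N)cc2)CC1`, gives 87.4%
compound 3, `CN(Cc1ccncc1)C(=S)SCc1ccc(C(=O)Nc2ccccc2N)cc1`, gives 86.1%

Compound 1 stands lowest of the three. Its nearest neighbour is compound 3, and the gap between them lies within the scatter; compound 2 lies beyond the scatter above it.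

Compound 4, `Nc1ccccc1NC(=O)c1ccc(CSC(=S)N2CCN(C3CCCCC3)CC2)cc1`, differs from compound 1 in one place: cyclohexyl in place of 4-fluorophenyl on an amine nitrogen in a ring.

Going by the values given here, only one measured step is at hand, a number 1.3 percentage points lower from compound 2 to compound 3 (within the scatter). It sits on the thiocarbonyl carbon, not on the amine nitrogen in the ring, so it does not bear directly on the change at hand; it does show that exchanging one nitrogen-bound group for another there left the number within the scatter. Among the compounds with values here, no measured pair tells what exchanging a 4-fluorophenyl for a cyclohexyl does on the ring nitrogen.

Compound 4 is therefore expected to show a number 2.7 percentage points higher from compound 1 to compound 4 (within the scatter), a step not beyond the scatter. The estimate for compound 4 is 79%, with a range from 64% to 92%.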

Compound 4, a percentage reported as inhibition, at one concentration (the size of the read-out at that concentration, not a potency): 89.9%
Estimate against measurement, compound 4: 10.9 percentage points below, and the stated range covers the measured number.
By their numbers in this assay, from the lowest: compounds 1, 3, 2 and 4 (each within the scatter of the next, the first and the last beyond it).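

Going by these compounds alone, exchanging 4-fluorophenyl for cyclohexyl on an amine nitrogen in a ring gives a number 13.6 percentage points higher from compound 1 to compound 4 (beyond the scatter) in this assay, so the number here does depend on the group this nitrogen carries, which no earlier pair could show. The exchange changes two things at once: an aromatic ring of carbon gives way to a non-aromatic one, and the fluorine leaves, and this one pair cannot tell these two changes apart. Nothing available here accounts for the rise.

What the compounds shown leave open is how a plain phenyl, without fluorine, would read on the same nitrogen, which would begin to separate those two changes. Also open, going by these compounds, is whether an open chain such as hexyl or a small group such as methyl would hold the number there.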